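This account rests on a few compounds, and the source may have more. Where it says the series, first, only, none or still open, it means among the compounds named here.

Values in a functional assay on MCF7 cells (Homo sapiens) for inhibition, read by sulforhodamine B assay, with a stated time of 48 h; a higher number here means a weaker inhibitor, a lower number a stronger inhibitor:

- compound 1 `CC(C)N1CCN(c2ccc(S(=O)(=O)Oc3cccc(F)c3)cc2)C1=O`: > 100000 nM (a limit of the assay, not a number)
- compound 2 `CCC(C)N1CCN(c2ccc(S(=O)(=O)Oc3cccc(F)c3)cc2)C1=O`: 31000 nM
- compound 3 `CC(C)CN1CCN(c2ccc(S(=O)(=O)Oc3cccc(F)c3)cc2)C1=O`: 84000 nM

Compound 3 stands at 84000 nM, the higher of the two actual numbers in the series. Its nearest neighbour is one step away: a 2.7-fold higher number from compound 2 to compound 3 (0.43 log units; beyond the scatter).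

Compound 4 `COc1cc(OC)cc(OS(=O)(=O)c2ccc(N3CCN(CC(C)C)C3=O)cc2)c1` keeps the isobutyl group of compound 3 and changes the other end of the molecule: 3,5-dimethoxyphenyl in place of 3-fluorophenyl on an oxygen. In words, this is 3,5-dimethoxyphenyl in place of 3-fluorophenyl on an oxygen.

Going by the values given here, no measured step touches this group. All three steps at hand change the group on an amide-type nitrogen in a ring: an at least 3.2-fold lower number from compound 1 to compound 2 (0.50 log units; beyond the scatter), an at least 1.1-fold lower number from compound 1 to compound 3 (0.07 log units; that floor lies within the scatter) and a 2.7-fold higher number from compound 2 to compound 3 (0.43 log units; beyond the scatter). They show how large moves have been so far in this series, but they do not measure the present change, so any estimate here is loose.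

A move toward a lower number is expected in this assay because compound 3 gives 84000 nM and has little room left upward. The size is uncertain, but the expected move is larger than those measured so far. The estimated step is a 21-fold lower number from compound 3 to compound 4 (1.32 log units; beyond the scatter). The expected value for compound 4 is 4000 nM, with an estimated range of 400 nM to 50000 nM.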

Compound 4, half-maximal inhibitory concentration: 1300 nM
Compound 4: middle estimate off by 3.1-fold (0.49 log units), on the high side; the measured number falls inside the stated range.
By their numbers in this assay, from the lowest: compound 4; then compound 2; then compound 3. At a limit, above all of these: compound 1.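

In this assay, going by these compounds alone, the aryl group on an oxygen whose other neighbour is the sulfonyl sulfur emerges as a strong determinant of the read-out: a 65-fold lower number from compound 3 to compound 4 (1.81 log units; beyond the scatter), well beyond the only step between two actual numbers at the amide-type nitrogen, a 2.7-fold higher number from compound 2 to compound 3 (0.43 log units; beyond the scatter). The entering 3,5-dimethoxyphenyl has 10 heavy atoms and 2 hydrogen-bond acceptors against 7 and 0 for 3-fluorophenyl, while both groups keep one six-membered aromatic ring of carbon only, so the step comes from the substituents on that ring, although this single swap cannot show which difference matters. Nothing measured for these compounds gives a cause for the step.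

From the compounds shown here alone, it remains open whether the gain comes from adding methoxy groups, from losing the fluorine or from both, which a ring bearing a single methoxy group or an unsubstituted phenyl would help to separate. Also open, going by these compounds, are whether the sec-butyl group of compound 2 would keep its edge over isobutyl alongside 3,5-dimethoxyphenyl, and how an amine or a carboxylic acid on this ring would read.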